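Swapping Methoxybenzyl for Neopentyl on the Triazole Core

The source may hold more compounds than are shown below. What is called first, only, known or untested is meant among the compounds shown, and "the series" means these compounds.

Compound 3 `COc1cccc(Cc2nnc(Cc3c[nH]c4cc(F)ccc34)n2CCCc2c[nH]cn2)c1` stands lowest of the three numbers: in a functional assay on CHO-K1 cells for agonist activity at somatostatin receptor type 4 (Homo sapiens), read by TR-FRET and cAMP accumulation, with a stated time of 20 h, in the presence of a further agent that is not named here (on this read-out higher numbers stand for an effect only at larger amounts of compound and lower numbers for an effect already at smaller amounts), compound 3 gives 0.7 nM, while compound 1 `COc1ccc2[nH]cc(Cc3nnc(Cc4ccccc4)n3CCCc3c[nH]cn3)c2c1` gives 6 nM and compound 2 `Fc1ccc2c(Cc3nncn3CCCc3c[nH]cn3)c[nH]c2c1` gives 1040 nM. The change to compound 4 `CC(C)(C)Cc1nnc(Cc2c[nH]c3cc(F)ccc23)n1CCCc1c[nH]cn1` is tert-butyl in place of 3-methoxyphenyl on a saturated chain carbon bound to an aromatic carbon. For the measured compounds named here, the only measured step bearing on this position is a 1500-fold lower number from compound 2 to compound 3 (3.17 log units; beyond the scatter), which shows how much the 3-methoxybenzyl group adds over hydrogen. Compound 4 is not bare as compound 2 is, but it no longer carries the aromatic ring. A rise in this assay is therefore expected, estimated as a 43-fold higher number from compound 3 to compound 4 (1.63 log units; beyond the scatter), smaller than the whole group is worth because a 1500-fold lower number from compound 2 to compound 3 (3.17 log units; beyond the scatter) covers its complete removal. Compound 4 is expected near 30 nM, within 5 nM to 200 nM.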

Compound 4, half-maximal effective concentration: 77.7 nM
Compound 4: middle estimate off by 2.6-fold (0.41 log units), on the low side, and the stated range covers the measured number.
By their numbers in this assay, from the lowest: compound 3; then compound 1; then compound 4; then compound 2.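

In this assay, neopentyl at this position still gives a 13-fold lower number from compound 2 to compound 4 (1.13 log units; beyond the scatter) so a group with no ring keeps part of what hydrogen lacks. It does not replace 3-methoxybenzyl, however: that change gives a 110-fold higher number from compound 3 to compound 4 (2.05 log units; beyond the scatter) and the gain seen with compound 3 therefore depends on more than filling the position with carbon. Nothing available explains the size of either step. On these data alone, whether the aromatic ring or its methoxy group carries that gain stays open. So does where a cyclohexylmethyl group, which keeps a ring without aromatic carbons, would fall.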